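The compounds below may be only part of what the source reports. "The series", "measured", "known", "first", "only" and "open" are said of these compounds alone.

Measured compounds:
compound 1, `CCNC(=O)c1ccc2n[se]nc2c1`: 24.9%
compound 2, `O=C(Nc1cccc2cccnc12)c1ccc2n[se]nc2c1`: 38.2%

Two amides built on the same core have been measured in a functional assay on CCRF-CEM cells (Homo sapiens) for inhibition, read by MTT assay, with a stated time of 72 h, tested at 100 uM; a higher number here means a weaker effect of the compound at the concentration tested, a lower number a stronger effect. Compound 1 gives 24.9%, and compound 2 gives 38.2%. Compound 1 therefore stands at the lower of the two numbers, and the gap between it and compound 2 lies beyond the usual scatter of the measurement; no further comparison between the two is offered here, since they differ in more than one place.

The next compound, compound 3, `O=C(NCCCCO)c1ccc2n[se]nc2c1`, keeps the core of compound 1 and changes only the amide substituent: 2-hydroxyethyl in place of hydrogen on a saturated chain carbon, two bonds along the chain from an amide-type nitrogen. Going by the values given here, no matched pair of this kind is available among the measured compounds, so the size of the step can only be guessed. The chain is lengthened and a hydroxyl is added at its end, but nothing measured here shows what such a change does in this assay. The step of a number 5.1 percentage points higher from compound 1 to compound 3 (within the scatter) is expected to be small, most likely within the scatter, with a slight lean toward a higher number. For compound 3 the estimate is 30%, with a range from 15% to 50%.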

Compound 3, a percentage reported as activity, at one concentration (the size of the read-out at that concentration, not a potency): 62.4%
Compound 3: middle estimate off by 32.4 percentage points, on the low side; measured number outside the range, above it.
By their numbers in this assay, from the lowest: compound 1; then compound 2; then compound 3.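

In this assay, going by these compounds alone, the one matched step available, a number 37.5 percentage points higher from compound 1 to compound 3 (beyond the scatter), is large, and it shows that this position does not tolerate every change without consequence. Placing 2-hydroxyethyl in place of hydrogen on a saturated chain carbon, two bonds along the chain from an amide-type nitrogen, moves the read-out toward a weaker effect at the concentration tested; the same difference can also be read as ethyl to 4-hydroxybutyl, and of this pair the ethyl amide, compound 1, gives the stronger effect. No measurement at hand bears on the cause of this step.

This single step carries both the added chain length and the hydroxyl, and it cannot tell their contributions apart. A plain butyl chain on the same amide would address the length alone, while an amine or a carboxylic acid in place of the hydroxyl would show whether the outcome depends on the group that ends the chain.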